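Adding a methoxy to compound 1: expected effect on cytotoxicity

The source may hold more compounds than are shown below. What is called first, only, known or untested is meant among the compounds shown, and "the series" means these compounds.

Measured compounds:
compound 1, `COc1ccc(C(=O)/C=C/c2cc(-c3cc(OC)c(OC)c(OC)c3)n[nH]2)cc1OC`: 88%
compound 2, `COc1cc(-c2cc(/C=C/C(=O)c3ccc(F)c(F)c3)[nH]n2)cc(OC)c1OC`: 93%

In a functional assay on OVCAR-5 cells (Homo sapiens) for cytotoxicity, read by sulforhodamine B assay, with a stated time of 48 h, tested at 0.1 uM (a lower number here means a stronger effect, a higher number a weaker effect of the compound at the concentration tested), compound 1 gives 88%, the lowest of the two numbers measured, while compound 2 in this assay gives 93%. Going by the values given here, the only measured step, a number 5 percentage points higher from compound 1 to compound 2 (within the scatter), shows that exchanging the group on the carbonyl carbon left the read-out unchanged beyond the scatter. Compound 3, `COc1cc(C(=O)/C=C/c2cc(-c3cc(OC)c(OC)c(OC)c3)n[nH]2)cc(OC)c1OC`, is not yet measured. It differs from compound 1 in one place: methoxy in place of hydrogen on an aromatic carbon. Among the compounds with values here, no measured step covers this exact change; the one step available, on the same part of the core, was within the scatter. The account therefore expects no step beyond the scatter for no change at the digits printed from compound 1 to compound 3 (within the scatter). Compound 3 is estimated to give 88% in this assay, with a range from 72% to 100%.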

Compound 3, a percentage reported as activity, at one concentration (the size of the read-out at that concentration, not a potency): 101%
For compound 3 the middle estimate is 13 percentage points below the measured one, and the stated range ends below it.
By their numbers in this assay, from the lowest: compounds 1, 2 and 3 (each within the scatter of the next, the first and the last beyond it).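

In this assay, methoxy in place of hydrogen on an aromatic carbon, ortho to a methoxy group and meta to a large group, gives a number 13 percentage points higher from compound 1 to compound 3 (beyond the scatter). Going by these compounds alone, this is the first step to pass the scatter, and it points to a weaker effect, whereas the earlier exchange on the same carbonyl-bound ring, a number 5 percentage points higher from compound 1 to compound 2 (within the scatter), showed no change that could be told from the scatter. Nothing available bears on why this modest step occurs.

The compounds shown leave open whether the weaker effect belongs to methoxy itself or would also appear with another group at this position, such as a hydroxyl or an amine. They also leave open how the compounds compare at other concentrations, since each read-out comes from a single concentration and is not a potency.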